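The compounds below may be only part of what the source reports. "The series", "measured", "known", "first", "only" and "open" are said of these compounds alone.

In a functional assay on cells (Platelet, Oryctolagus cuniculus) for inhibition, read by turbidimetry, with a stated time of 5 min (a higher number here means a weaker inhibitor, a lower number a stronger inhibitor), compound 1 (`CCCC[C@H](OC(C)=O)c1ccccc1C(=O)O[C@H]1CO[C@H]2[C@@H]1OC[C@H]2OC(=O)c1ccccc1[C@H](CCCC)OC(C)=O`) gives 330000 nM and is the weaker inhibitor of the two measured compounds. Compound 2 (`CCCC[C@H](OC(=O)CN1CCN(C)CC1)c1ccccc1C(=O)O[C@H]1CO[C@H]2[C@@H]1OC[C@H]2OC(=O)c1ccccc1[C@H](CCCC)OC(=O)CN1CCN(C)CC1`) gives 70000 nM as the lower number. Compound 3 (`CCCC[C@@H](OC(C)=O)c1ccccc1C(=O)O[C@H]1CO[C@H]2[C@@H]1OC[C@H]2OC(=O)c1ccccc1[C@@H](CCCC)OC(C)=O`) differs from compound 1 only in configuration: the two compounds have the same atoms and bonds and differ only in configuration as drawn: 2 of 6 stereo elements differ; a stereocentre at a saturated chain carbon is drawn S in compound 1 and R in compound 3; a stereocentre at a saturated chain carbon is drawn S in compound 1 and R in compound 3 is the whole difference. Within the data shown here, no measured pair shows what such a change does, so no step beyond the scatter is expected in this assay here. The estimated move is a 1.1-fold lower number from compound 1 to compound 3 (0.04 log units; within the scatter) and it is expected to stay within the scatter. Compound 3 is expected at 300000 nM with an estimated range from 100000 nM to 800000 nM in this measurement.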

Compound 3, half-maximal inhibitory concentration: 710000 nM
For compound 3 the middle estimate is 2.4-fold (0.37 log units) below the measured one; the range from low to high includes it.
By their numbers in this assay, from the lowest: compound 2; then compound 1; then compound 3.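

Among these compounds, the step of a 2.2-fold higher number from compound 1 to compound 3 (0.33 log units; beyond the scatter) in this assay gives the first reading of what configuration at these saturated chain carbons does, since no earlier pair of compounds differed in one place. It is modest but beyond the scatter, so the drawn configuration at these stereocentres is not neutral here, and the step can be assigned to configuration alone because of one fact: the fact that compounds 1 and 3 differ only in the configuration as drawn

Going by these compounds, both stereocentres change together, so the share of each remains open. Also open, on these data alone, is whether the same change would count where a carboxylic acid replaces the acetate esters.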